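The compounds below may be only part of what the source reports. "The series", "measured", "known", "first", "only" and "open" are said of these compounds alone.

For the measured compounds named here, in a functional assay on CCRF-CEM cells (Homo sapiens) for antiproliferative activity (on this read-out lower numbers stand for stronger inhibition and higher numbers for weaker inhibition), compound 3 `COc1cc(C(=O)c2sc(-c3ccc(Cl)c(Cl)c3)cc2N)cc(OC)c1OC` gives 290 nM, the highest number of the three measured so far. Compound 2 `COc1cc(C(=O)c2sc(-c3ccc(Cl)cc3)cc2N)cc(OC)c1OC` gives 70 nM, and compound 1 `COc1ccc(-c2cc(N)c(C(=O)c3cc(OC)c(OC)c(OC)c3)s2)cc1OC` gives 20 nM. Compound 4 `COc1ccc(-c2cc(N)c(C(=O)c3cc(OC)c(OC)c(OC)c3)s2)cc1` is unmeasured: 4-methoxyphenyl in place of 3,4-dichlorophenyl on an aromatic carbon, next to the ring sulfur (4-methoxyphenyl in place of 3,4-dichlorophenyl on an aromatic carbon). The nearest evidence is a 15-fold higher number from compound 1 to compound 3 (1.16 log units; beyond the scatter), a large step, made up of two modest ones: a 3.5-fold higher number from compound 1 to compound 2 (0.54 log units; beyond the scatter) and a 4.1-fold higher number from compound 2 to compound 3 (0.62 log units; beyond the scatter). Going by the values given here, no measured compound carries 4-methoxyphenyl, so the read-across from compound 1 is indirect. The expected change is a 12-fold lower number from compound 3 to compound 4 (1.06 log units; beyond the scatter), a large step toward a lower number in this assay. Compound 4 is estimated at 25 nM, with an expected range of 8 nM to 80 nM.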

Compound 4, half-maximal inhibitory concentration: 19 nM
Compound 4: the middle estimate sits 1.3-fold (0.12 log units) above what was measured; measured number inside the range.
By their numbers in this assay, from the lowest: compounds 4 and 1 (each within the scatter of the next); then compound 2; then compound 3.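

In this assay, 4-methoxyphenyl in place of 3,4-dichlorophenyl on the aromatic carbon next to the ring sulfur gives a 15-fold lower number from compound 3 to compound 4 (1.18 log units; beyond the scatter) and methoxy in place of chloro alone gives a 3.7-fold lower number from compound 2 to compound 4 (0.57 log units; beyond the scatter) so both compounds carrying chloro give higher numbers than compound 4. Hydrogen in place of methoxy gives a 1.1-fold lower number from compound 1 to compound 4 (0.02 log units; within the scatter) so 4-methoxyphenyl and 3,4-dimethoxyphenyl cannot be told apart here. No measurement on hand accounts for these steps.

Still open, as far as these compounds go, is how plain phenyl, or a hydroxy, ethoxy or dimethylamino group in place of the methoxy, would read.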